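Cyclopropyl on the Amide Nitrogen of a Difluoro Analogue

The source may report more compounds than this note shows. Statements on the series, on what has been measured and on what is new or still open speak of the compounds shown alone.

Three compounds share one core: compound 1 `CNC(=O)/C=C1\CCc2cc(F)c(F)cc21`, compound 2 `O=C(/C=C1\CCc2cc(Cl)ccc21)NC1CC1` and compound 3 `NC(=O)/C=C1\CCc2cc(F)c(F)cc21`. In a functional assay on the whole organism with Mus musculus as the target, at a dose of 100 mg/kg by the intraperitoneal route (on this read-out lower numbers stand for less inhibition and higher numbers for more inhibition at the one dose given (going by the name of the read-out)), compound 1 gives 100%, compound 2 gives 17% and compound 3 gives 100%. Compound 3 thus stands level with compound 1 at the top of the three numbers, while compound 2 lies far beneath both, beyond the scatter. The step of no change at the digits printed from compound 1 to compound 3 (within the scatter) shows that the amide nitrogen carries hydrogen as well as it carries methyl.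

Compound 4 `O=C(/C=C1\CCc2cc(F)c(F)cc21)NC1CC1` has not been measured. It differs from compound 3 in one place: cyclopropyl in place of hydrogen on an amide-type nitrogen. Within the data shown here, the only measured step at that nitrogen is no change at the digits printed from compound 1 to compound 3 (within the scatter), which bears on the change but involves a smaller group. Compound 2 also carries cyclopropyl on its amide nitrogen, yet it differs from compound 3 in a second place as well, so its low value cannot be laid to the cyclopropyl alone. Compound 4 is therefore expected to show a step of a number 30 percentage points lower from compound 3 to compound 4 (beyond the scatter), downward but of uncertain size. The estimate for compound 4 is 70%, ranging from 20% to 100%.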

Compound 4, a percentage reported as inhibition, in the whole organism at one dose (the size of the read-out at that dose, not a potency): 50%
Beside the measured number, compound 4's estimate is 20 percentage points above it; the range from low to high includes it.
By their numbers in this assay, from the lowest: compound 2; then compound 4; then compounds 1 and 3 (each within the scatter of the next).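

In this assay the amide nitrogen turns out not to accept every group alike, since cyclopropyl gives a number 50 percentage points lower from compound 3 to compound 4 (beyond the scatter) and likewise a number 50 percentage points lower from compound 1 to compound 4 (beyond the scatter), a loss that the hydrogen and methyl pair had given no sign of. The loss is only partial, as compound 4 still gives 50%, so on the difluoro core the cyclopropyl group lowers the read-out at this nitrogen without abolishing it. Nothing at hand says what lies behind this drop.

The compounds shown leave open whether the fall depends on the ring itself, which an open chain such as ethyl or isopropyl on the same nitrogen would address. They also leave open how a larger ring such as cyclobutyl, or a second methyl on that nitrogen, would read out at this dose.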